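Notes on the aryl-sulfonamide series: acidic side chain at the ring nitrogen

This account rests on a few compounds, and the source may have more. Where it says the series, first, only, none or still open, it means among the compounds named here.

Measured so far:
compound 1 `COc1nn(CC(N)=O)c2ncnc(NS(=O)(=O)c3cccc(Cl)c3Cl)c12` — 501 nM
compound 2 `CNC(=O)Cn1nc(OC)c2c(NS(=O)(=O)c3cccc(Cl)c3Cl)ncnc21` — 631 nM
compound 3 `COc1nn(C2COC2)c2ncnc(NS(=O)(=O)c3cccc(Cl)c3Cl)c12` — 251 nM

In a functional assay on cells for antagonist activity at C-C chemokine receptor type 4 (Homo sapiens), read by GTPgammaS binding (a higher number here means a weaker inhibitor, a lower number a stronger inhibitor), compound 3 has the lowest number of the three; its gap to compound 1 is within the scatter, while the step of a 2.5-fold lower number from compound 2 to compound 3 (0.40 log units; beyond the scatter) is beyond it. Compound 4 `COc1nn(CC(=O)O)c2ncnc(NS(=O)(=O)c3cccc(Cl)c3Cl)c12` carries the change (carboxymethyl in place of oxetan-3-yl on an aromatic nitrogen). Going by the values given here, the steps that bear on it are a 2.0-fold lower number from compound 1 to compound 3 (0.30 log units; within the scatter) and a 2.5-fold lower number from compound 2 to compound 3 (0.40 log units; beyond the scatter), both replacing an amide-type chain at this position by oxetan-3-yl; no compound with a carboxylic acid at this position has been measured. Moving back to a two-carbon chain is therefore expected to give a higher number again, roughly a 2.5-fold higher number from compound 3 to compound 4 (0.40 log units; beyond the scatter), so compound 4 is estimated at 630 nM, range 250 nM to 1600 nM.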

Compound 4, half-maximal inhibitory concentration: 200 nM
Compound 4: the middle estimate sits 3.2-fold (0.50 log units) above what was measured, and the stated range ends above it.
By their numbers in this assay, from the lowest: compounds 4, 3, 1 and 2 (each within the scatter of the next, the first and the last beyond it).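

In this assay, hydroxy on the carbonyl carbon gives a lower number than either amide end: a 2.5-fold lower number from compound 1 to compound 4 (0.40 log units; beyond the scatter) and a 3.2-fold lower number from compound 2 to compound 4 (0.50 log units; beyond the scatter) are the steps. Against oxetan-3-yl, a 1.3-fold lower number from compound 3 to compound 4 (0.10 log units; within the scatter) shows that the open carboxymethyl chain and the four-membered ring cannot be told apart at this position. Nothing at hand explains the gap between the carboxylic acid and the amides.

Still open, on these data alone, is how a longer chain ending in a carboxylic acid would compare with carboxymethyl. An amine at the end of the chain also remains untested among the compounds shown.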